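The source may hold more compounds than are shown below. What is called first, only, known or untested is meant among the compounds shown, and "the series" means these compounds.

Measured compounds:
- Compound 1, `CCOC(=O)C(=O)C(CC)NC(=O)C(CC(C)C)NC(=O)CCCCc1ccccc1`, gives 1900 nM in an assay on isolated protein (Oryctolagus cuniculus) for inhibition of Calpain-2 catalytic subunit (Homo sapiens), at pH 8.0; on this read-out higher numbers stand for weaker inhibition and lower numbers for stronger inhibition.
- Compound 2, `CCOC(=O)C(=O)[C@H](CC)NC(=O)[C@H](CC(C)C)NC(=O)[C@H](CC(C)C)NS(=O)(=O)c1ccc2ccccc2c1`, gives 1400 nM in this assay.
- Compound 3, `CCCCNC(=O)C(=O)C(CC)NC(=O)C(CC(C)C)NC(=O)OCc1ccccc1`, gives 50 nM in this assay.

Compound 3 has the lowest number of the three, and both other compounds lie beyond the scatter from it, so compound 3 is the strongest inhibitor among them. Compound 4, `CCCCCCCCNC(=O)C(=O)C(CC)NC(=O)C(CC(C)C)NC(=O)OCc1ccccc1`, differs from compound 3 only at the end of the amide chain: butyl in place of hydrogen on a saturated chain carbon, four bonds along the chain from an amide-type nitrogen. Going by the values given here, no measured pair shows a step of this kind, so the expectation rests on compound 3 alone. A change of this size, on a chain away from the shared core, is expected to move the number little, possibly within the scatter in either direction. Compound 4 is therefore estimated at 40 nM, with a range from 12 nM to 150 nM, meaning an expected step of a 1.3-fold lower number from compound 3 to compound 4 (0.10 log units; within the scatter).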

Compound 4, inhibition constant: 19 nM
Compound 4: middle estimate off by 2.1-fold (0.32 log units), on the high side; low and high end bracket the measured number.
By their numbers in this assay, from the lowest: compound 4; then compound 3; then compounds 2 and 1 (each within the scatter of the next).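

In this assay, butyl in place of hydrogen on a saturated chain carbon, four bonds along the chain from an amide-type nitrogen, gives a 2.6-fold lower number from compound 3 to compound 4 (0.42 log units; beyond the scatter), a modest step beyond the scatter. This position therefore accepts extra chain carbons without loss of inhibition, and here the added butyl strengthens it. Nothing measured here explains this step. A single step cannot show whether a longer chain would strengthen inhibition further. From the compounds shown here alone, how an amine or a carboxylic acid at this position would compare also remains open.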